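The source may hold more compounds than are shown below. What is called first, only, known or untested is meant among the compounds shown, and "the series" means these compounds.

Of the compounds shown here, two have been measured in a functional assay on MCF7 cells (Homo sapiens) for antiproliferative activity, with a stated time of 5 days; on this read-out lower numbers stand for stronger inhibition and higher numbers for weaker inhibition. Compound 1 `COc1ccc(-c2[nH]c3ccc(F)cc3c2C=C(C#N)C#N)cc1` gives 310 nM, and compound 2 `CCCCCCc1ccc2[nH]c(-c3ccc(OC)cc3)c(C=C(C#N)C#N)c2c1` gives 25 nM, the lower of the two numbers. Among the measured compounds shown here, the only measured step is a 12-fold lower number from compound 1 to compound 2 (1.09 log units; beyond the scatter), with hexyl in place of fluoro on an aromatic carbon. Compound 3 `CCCCCCc1ccc2[nH]c(-c3ccc(C(F)(F)F)cc3)c(C=C(C#N)C#N)c2c1` keeps the hexyl of compound 2 and differs elsewhere: trifluoromethyl in place of methoxy on an aromatic carbon, para to a large group. The measured step lies at another place, so it does not bear directly on this change, and its large size cannot be carried over. With nothing measured at this place, the expectation starts from compound 2 at 25 nM, and a moderately higher number is expected, although a change within the scatter remains possible. The estimated step is a 2.4-fold higher number from compound 2 to compound 3 (0.38 log units; beyond the scatter). For compound 3 the expected value is 60 nM, with an estimated range from 15 nM to 250 nM.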

Compound 3, half-maximal inhibitory concentration: 68 nM
Compound 3: middle estimate off by 1.1-fold (0.05 log units), on the low side, within the range that was stated.
By their numbers in this assay, from the lowest: compound 2; then compound 3; then compound 1.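

In this assay, trifluoromethyl in place of methoxy on an aromatic carbon, para to a large group, gives a 2.7-fold higher number from compound 2 to compound 3 (0.43 log units; beyond the scatter), so the number at this position does respond to the group it carries. With hexyl kept on the shared core, methoxy is the group with the lower number of these two, yet the change away from it costs only a modest step and does not lose the activity. The data shown offer nothing that explains this difference.

The compounds shown leave open how a hydroxy group, an amine or a plain hydrogen would read at this place. They also leave open whether this change gives a step of similar size with fluoro instead of hexyl on the core, and how a chain longer than hexyl would read.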